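Stripping the Sulfamoyl Group from the Piperazin-1-yl Ring

This account rests on a few compounds, and the source may have more. Where it says the series, first, only, none or still open, it means among the compounds named here.

In an ADME assay on MT4 cells (Homo sapiens) for cytotoxicity, read by MTT assay, with a stated time of 5 days (on this read-out higher numbers stand for lower toxicity in this test and lower numbers for higher toxicity in this test), compound 1 (`Cc1cc(/C=C/C#N)cc(C)c1Oc1nc(Nc2ccc(N3CCCC(NS(N)(=O)=O)C3)cc2)nc2sccc12`) is recorded only as a limit, > 217000 nM. On these data alone, compound 2 (`Cc1cc(/C=C/C#N)cc(C)c1Oc1nc(Nc2ccc(N3CCN(S(N)(=O)=O)CC3)cc2)nc2sccc12`) is likewise recorded only as a limit, > 222000 nM, so its exact standing is unknown. Compound 3 (`Cc1cc(/C=C/C#N)cc(C)c1Oc1nc(Nc2ccc(N3CCNCC3)cc2)nc2sccc12`) differs from it by hydrogen in place of sulfamoyl on an amine nitrogen in a ring. For the measured compounds named here, the one measured step, a step that the two limits leave unreadable from compound 1 to compound 2, bears on this change but gives no usable size. On the structural change alone, the expected move is towards higher toxicity, with an estimated at least 7.4-fold lower number from compound 2 to compound 3 (0.86 log units; beyond the scatter). For compound 3, the estimate in this assay is 30000 nM, with an expected range of 6000 nM to 150000 nM.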

Compound 3, half-maximal cytotoxic concentration: 4740 nM
Estimate against measurement, compound 3: 6.3-fold (0.80 log units) above, and the stated range ends above it.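

Hydrogen in place of sulfamoyl on the amine nitrogen in the ring gives an at least 46-fold lower number from compound 2 to compound 3 (1.67 log units; beyond the scatter) in this assay and so marks this nitrogen as a place where toxicity in this test rises sharply. Piperazin-1-yl in place of 3-(sulfamoylamino)piperidin-1-yl gives an at least 45-fold lower number from compound 1 to compound 3 (1.66 log units; beyond the scatter) as a step of the same direction. Compound 1 and compound 2 stand only as limits, and the step between them cannot be read. The compounds shown leave open whether the unsubstituted ring nitrogen itself goes with the lower number. An acetyl or a methyl group on that nitrogen would bear on this.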